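Swapping Thiophene for Pyridine: Expected Cytotoxicity of Compound 4

The compounds below may be only part of what the source reports. "The series", "measured", "known", "first", "only" and "open" are said of these compounds alone.

Measured so far:
Compound 1, `Oc1ccc(-c2cc(-c3ccc(Cl)cc3)nc(-c3cccnc3)c2)cc1`: 27500 nM
Compound 2, `Oc1ccc(-c2cc(-c3ccc(Cl)cc3)nc(-c3cccs3)c2)cc1`: 4520 nM
Compound 3, `Oc1ccc(-c2cc(-c3cccc(Cl)c3)nc(-c3cccs3)c2)cc1`: 2720 nM

These three compounds share a core and were tested in an ADME assay on HEK293 cells (Homo sapiens) for cytotoxicity, read by CCK-8 assay and cell counting, with a stated time of 2 days; on this read-out higher numbers stand for weaker inhibition and lower numbers for stronger inhibition. Compound 2 and compound 3 have the same atoms joined differently: 3-chlorophenyl in place of 4-chlorophenyl on an aromatic carbon. The step is a 1.7-fold lower number from compound 2 to compound 3 (0.22 log units; within the scatter), so the two cannot be told apart here. Compound 1 and compound 2 differ in another way: pyridin-3-yl in place of thiophen-2-yl on an aromatic carbon. Here the step is a 6.1-fold higher number from compound 2 to compound 1 (0.78 log units; beyond the scatter).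

Compound 4, `Oc1ccc(-c2cc(-c3cccnc3)nc(-c3cccc(Cl)c3)c2)cc1`, has not yet been tested in this assay. It differs from compound 3 as follows: pyridin-3-yl in place of thiophen-2-yl on an aromatic carbon. Among the measured compounds shown here, this is the same kind of change as the one separating compound 2 from compound 1, but the surroundings are not identical: in compound 4 the entering group sits meta to a 3-chlorophenyl group, whereas in compound 1 it sits meta to a 4-chlorophenyl group. For the measured compounds named here, only one example of this change has been measured, so the expectation for compound 4 rests on it alone. The expected step is a 6.1-fold higher number from compound 3 to compound 4 (0.78 log units; beyond the scatter), because the same change gave a 6.1-fold higher number from compound 2 to compound 1 (0.78 log units; beyond the scatter). On this basis compound 4 is estimated to give 16500 nM in this assay, with a likely range from 6000 nM to 45000 nM.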

Compound 4, half-maximal inhibitory concentration: 25700 nM
Estimate against measurement, compound 4: 1.6-fold (0.19 log units) below; low and high end bracket the measured number.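

In this assay, putting pyridin-3-yl in place of thiophen-2-yl gives a 9.4-fold higher number from compound 3 to compound 4 (0.98 log units; beyond the scatter), and this step matches the one seen earlier for the same change on the partner compounds carrying a 4-chlorophenyl group: the same change on two cores in this assay, a 6.1-fold higher number (0.78 log units; beyond the scatter) from compound 2 to compound 1 and a 9.4-fold higher number (0.98 log units; beyond the scatter) from compound 3 to compound 4, 1.6-fold (0.19 log units) apart, within the scatter of two such steps

The other change, 3-chlorophenyl in place of 4-chlorophenyl, gives a 1.1-fold lower number from compound 1 to compound 4 (0.03 log units; within the scatter), so compound 1 and compound 4 cannot be told apart, and this small step also repeats across the two pairs: the same change on two cores in this assay, a 1.7-fold lower number (0.22 log units; within the scatter) from compound 2 to compound 3 and a 1.1-fold lower number (0.03 log units; within the scatter) from compound 1 to compound 4, 1.6-fold (0.19 log units) apart, within the scatter of two such steps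

Together, these four compounds show that in this small set each change has about the same effect whichever form of the other group is present, but this rests on only one pair of steps for each change, among close relatives, and it does not show why the numbers move or that the same would hold on a more different core.

The compounds shown leave open whether the pyridin-3-yl step would persist if the hydroxy group of the 4-hydroxyphenyl group were replaced by a methoxy group or an amine. They also leave open what a carboxylic acid or a longer alkyl chain in place of the chlorine would do to the numbers in this assay.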